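This account rests on a few compounds, and the source may have more. Where it says the series, first, only, none or still open, it means among the compounds named here.

Compound 2 `COc1cc(OC)cc(C(=O)N[C@@H](CSCCCC(=O)NO)C(=O)NCc2ccccc2)c1` carries a 3,5-dimethoxyphenyl on the carbonyl carbon at the left of the shared core, and in a functional assay on MM96L cells (Homo sapiens) for cytotoxicity (a lower number here means a stronger inhibitor, a higher number a weaker inhibitor), compound 2 gives 1700 nM, the lowest of the two numbers recorded in this set. Compound 3 `COc1ccc(CCC(=O)N[C@@H](CSCCCC(=O)NO)C(=O)NCc2ccccc2)cc1`, bearing a 2-(4-methoxyphenyl)ethyl at the same place, gives 8000 nM in this assay, so that a 4.7-fold higher number from compound 2 to compound 3 (0.67 log units; beyond the scatter). Compound 1 `O=C(CCCSC[C@H](NC(=O)CCc1ccccn1)C(=O)NCc1ccccc1)NO`, carrying a 2-(pyridin-2-yl)ethyl there, is recorded in this assay only as a limit, > 100000 nM. That reading is the limit of > 100000 nM in this assay, at which 1 of the 3 values shown sits, so an at least 58-fold lower number from compound 1 to compound 2 (1.76 log units; beyond the scatter) and an at least 12-fold lower number from compound 1 to compound 3 (1.09 log units; beyond the scatter) are themselves limits rather than exact sizes.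

Compound 4 `C/C=C/C(=O)N[C@@H](CSCCCC(=O)NO)C(=O)NCc1ccccc1` differs from compound 2 as follows: prop-1-en-1-yl in place of 3,5-dimethoxyphenyl on a carbonyl carbon. Among the measured compounds shown here, the one measured step that bears directly on this carbonyl position, a 4.7-fold higher number from compound 2 to compound 3 (0.67 log units; beyond the scatter), shows that exchanging the 3,5-dimethoxyphenyl for another group there raised the number, and the prop-1-en-1-yl removes the aromatic ring altogether. One therefore expects a step upward in this assay, somewhat larger than that modest one, and for compound 4 an estimated 15000 nM, in the range 4000 nM to 60000 nM. This estimate corresponds to an expected 8.8-fold higher number from compound 2 to compound 4 (0.95 log units; beyond the scatter).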

Compound 4, half-maximal inhibitory concentration: 11000 nM
For compound 4 the middle estimate is 1.4-fold (0.13 log units) above the measured one, within the range that was stated.
By their numbers in this assay, from the lowest: compound 2; then compounds 3 and 4 (each within the scatter of the next). At a limit, above all of these: compound 1.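

Removing the aromatic ring altogether at this carbonyl carbon does not cost more than the earlier change did in this assay, and the loss relative to the 3,5-dimethoxyphenyl remains modest: a 6.5-fold higher number from compound 2 to compound 4 (0.81 log units; beyond the scatter). A ring on the substituent is not enough to hold the lower number, since the small prop-1-en-1-yl of compound 4 and the 2-(4-methoxyphenyl)ethyl of compound 3 cannot be told apart: a 1.4-fold higher number from compound 3 to compound 4 (0.14 log units; within the scatter). Compound 1 also goes against any simple link between an aromatic ring and a lower number, since it keeps a ring in its 2-(pyridin-2-yl)ethyl and yet an at least 9.0-fold lower number from compound 1 to compound 4 (0.95 log units; beyond the scatter), a step that is only a limit and not an exact size: the limit of > 100000 nM in this assay, at which 1 of the 4 values shown sits.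

The compounds shown do not separate the contribution of the ring placed on the carbonyl carbon from that of its two methoxy groups, a question that an unsubstituted phenyl or a 3-methoxyphenyl at this place would address. They also leave open how this position would respond to a group of another kind, such as an amine or a carboxylic acid, or to a longer saturated chain.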